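The source may hold more compounds than are shown below. What is called first, only, known or untested is meant among the compounds shown, and "the series" means these compounds.

Measured so far:
Compound 1, `Brc1ccc(-n2nncc2-c2cccnc2)cc1`, gives 87.2 mg/kg in a functional assay on the whole organism with Mus musculus as the target, in the maximal electroshock model; on this read-out higher numbers stand for an effect only at larger amounts of compound and lower numbers for an effect already at smaller amounts.
Compound 2, `c1ccc(-n2nncc2-c2ccccn2)cc1`, gives 41.1 mg/kg in this assay.

Compound 2 stands at the lowest of the two numbers seen here; its nearest neighbour is compound 1, whose value sits beyond the scatter above it. The two compounds differ from each other in more than one place, so their two values alone say nothing about any single change. The unmeasured compound 3, `Brc1ccc(-n2nncc2-c2ccccn2)cc1`, arises from compound 2 by a single alteration: bromo in place of hydrogen on an aromatic carbon. For the measured compounds named here, no measured pair isolates this change, and the only compound that carries a bromo group, compound 1, also differs from compound 2 elsewhere. The step from compound 2 to compound 3 in this assay is therefore expected to be small, most likely within the scatter, with a slight lean toward a higher number, as expressed by a 1.3-fold higher number from compound 2 to compound 3 (0.13 log units; within the scatter). Compound 3 is estimated to give 55 mg/kg in this assay, with a range from 28 mg/kg to 110 mg/kg.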

Compound 3, dose for half-maximal effect: 68 mg/kg
Compound 3: the middle estimate sits 1.2-fold (0.09 log units) below what was measured; measured number inside the range.
By their numbers in this assay, from the lowest: compounds 2, 3 and 1 (each within the scatter of the next, the first and the last beyond it).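

Compound 3 gives each earlier compound a partner that differs in one place, so single changes can now be read in this assay. On the aromatic carbon para to a large group, bromo in place of hydrogen gives a 1.7-fold higher number from compound 2 to compound 3 (0.22 log units; within the scatter), showing that this position carries the bromo group with no shift beyond the scatter. Pyridin-2-yl in place of pyridin-3-yl gives a 1.3-fold lower number from compound 1 to compound 3 (0.11 log units; within the scatter), so on the bromo-bearing compounds this change also stays within the scatter, and nothing available explains either step.

From the compounds shown here alone, what remains open is whether a different group at this position, such as an amine, a methoxy group or a carboxylic acid, would stay within the scatter of compound 2 as bromo does. Going by these compounds, each change is also seen only once, so it is open whether the step for bromo would hold with pyridin-3-yl in place of pyridin-2-yl on a compound carrying hydrogen at this position.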